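The source may report more compounds than this note shows. Statements on the series, on what has been measured and on what is new or still open speak of the compounds shown alone.

Compounds measured so far, with their values in a functional assay on HOS-TE85 cells (Homo sapiens) for inhibition, read by CCK-8 assay, with a stated time of 72 h; a lower number here means a stronger inhibitor, a higher number a weaker inhibitor:

Compound 1, `COc1ccccc1N1C(=O)C(C)SC1c1cccc(C(=O)NCCCCc2ccccc2)c1`, gives 45.1 nM.
Compound 2, `COc1c(F)cccc1N1C(=O)CSC1c1cccc(C(=O)NCCCCc2ccccc2)c1`, gives 26.2 nM.
Compound 3, `O=C(NCCCCc1ccccc1)c1cccc(C2SCC(=O)N2c2cnccn2)c1`, gives only a limit of the assay, > 1000 nM.

Compound 1 and compound 2 sit close together, within the usual scatter of this assay, so they cannot be ranked against each other. Compound 3 stands apart: the step of an at least 38-fold higher number from compound 2 to compound 3 (1.58 log units; beyond the scatter) shows that swapping the aryl group on the ring nitrogen for a pyrazin-2-yl group costs a great deal of potency, and compound 3 reaches (the limit of > 1000 nM in this assay, at which 1 of the 3 values shown sits).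

The unmeasured compound 4, `CC1SC(c2cccc(C(=O)NCCCCc3ccccc3)c2)N(c2cccc(C3CC3)c2)C1=O`, keeps the core of compound 1 and changes only the group on that same nitrogen: 3-cyclopropylphenyl in place of 2-methoxyphenyl on an amide-type nitrogen in a ring. Within the data shown here, the one measured step on this position is the large one from compound 2 to compound 3, but that step replaces a phenyl ring with a heteroaryl ring, whereas compound 4 still carries a phenyl ring, now substituted with cyclopropyl instead of methoxy. Among the measured compounds shown here, there is no measured step for trading one substituted phenyl for another. The expectation is therefore a small step, a 1.3-fold higher number from compound 1 to compound 4 (0.12 log units; within the scatter), in either direction and within the scatter. Compound 4 is estimated to give 60 nM in this assay, with a plausible range from 20 nM to 200 nM.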

Compound 4, half-maximal inhibitory concentration: 295 nM
Estimate against measurement, compound 4: 4.9-fold (0.69 log units) below; the measured number lies above the stated range.
By their numbers in this assay, from the lowest: compounds 2 and 1 (each within the scatter of the next); then compound 4. At a limit, above all of these: compound 3.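

At this nitrogen, keeping a phenyl ring does not by itself preserve potency: 3-cyclopropylphenyl in place of 2-methoxyphenyl gives a 6.5-fold higher number from compound 1 to compound 4 (0.82 log units; beyond the scatter) in this assay. Among these compounds, until now, the only measured change here was the replacement of a substituted phenyl with pyrazin-2-yl, so this result shows that the position also responds to a change from one substituted phenyl to another, with compound 4 a weaker inhibitor than compound 1. Nothing measured here explains this loss.

The compounds shown leave open whether the loss follows from replacing methoxy with cyclopropyl or from the different ring position of the substituent, a question that 3-methoxyphenyl or 2-cyclopropylphenyl on the same nitrogen would address. Also open, from the compounds shown here alone, is how a plain phenyl or a 3-aminophenyl group would behave here.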